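From Thiazole to Methylthiophene: Expected Cytotoxicity Shift

The source may hold more compounds than are shown below. What is called first, only, known or untested is meant among the compounds shown, and "the series" means these compounds.

Compound 1 `C[C@H]1[C@H](NCc2cncs2)C[C@H]2C[C@@H]1C2(C)C` carries a 1,3-thiazol-5-yl group on a saturated chain carbon bound to an amine nitrogen of the shared core. In an ADME assay on MDCK cells (Canis lupus familiaris) for cytotoxicity, read by microscopy, with a stated time of 48 h (a lower number here means that less compound is tolerated, a higher number that more compound is tolerated), compound 1 gives > 100000 nM, which is a limit of the assay rather than a number; this is the limit of > 100000 nM in this assay, at which 1 of the 3 values shown sits. Two thiophene analogues on the same core have measured numbers. Compound 2 `C=Cc1ccsc1CN[C@@H]1C[C@H]2C[C@@H]([C@H]1C)C2(C)C` gives 50000 nM in this assay, and compound 3 `CCc1ccsc1CN[C@@H]1C[C@H]2C[C@@H]([C@H]1C)C2(C)C` gives 25000 nM. The step between them, a 2.0-fold lower number from compound 2 to compound 3 (0.30 log units; within the scatter), places ethyl in place of vinyl on an aromatic carbon and lies within the scatter.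

Compound 4 `Cc1csc(CN[C@@H]2C[C@H]3C[C@@H]([C@H]2C)C3(C)C)c1` has not yet been measured in this assay. It differs from compound 1 in one place: 4-methylthiophen-2-yl in place of 1,3-thiazol-5-yl on a saturated chain carbon bound to an amine nitrogen. For the measured compounds named here, no measured step covers this exchange directly, so the expectation rests on compounds 2 and 3, both carrying a thiophene ring, which return numbers rather than a limit. The expected change is an at least 2.5-fold lower number from compound 1 to compound 4 (0.39 log units; beyond the scatter), a move to a lower number. Compound 4 is estimated at 40000 nM, with a range from 20000 nM to 100000 nM.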

Compound 4, minimum cytotoxic concentration: 12500 nM
Compound 4: middle estimate off by 3.2-fold (0.51 log units), on the high side; measured number below the stated range.
By their numbers in this assay, from the lowest: compounds 4, 3 and 2 (each within the scatter of the next, the first and the last beyond it). At a limit, above all of these: compound 1.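

In this assay, 4-methylthiophen-2-yl in place of 1,3-thiazol-5-yl on a saturated chain carbon bound to an amine nitrogen gives an at least 8.0-fold lower number from compound 1 to compound 4 (0.90 log units; beyond the scatter). This is the first step shown at this place that leads from a ring with 2 hetero atoms to a ring with 1 hetero atom, and it lies beyond the scatter. Its true size stays unknown, and it could be larger, as compound 1 stands at a limit of the assay and not at a number: the limit of > 100000 nM in this assay, at which 1 of the 4 values shown sits.

The exchange removes the ring nitrogen and brings in a methyl group at once, and the compounds shown do not separate the two, as a plain thiophen-2-yl group would begin to do. As far as these compounds go, how the same place responds to a ring bearing an amine or a carboxylic acid also stays open.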